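A few compounds are considered here, and "the series" means these few. Any claim that something is new, unique, unknown or untested is made for them only; others in the source may bear on it.

Working notes on the series.

Compound 1 `Cc1cc(COc2cccc(F)c2)nc(-c2ccccn2)n1` gives 3.1 in a physicochemical assay for lipophilicity, at pH 7.4; a lower number here means a more polar compound, a higher number a more lipophilic compound. Compound 2 `Cc1cc(COc2ccc(F)cc2)nc(-c2ccccn2)n1` gives 3 in this assay, and compound 3 `Cc1cc(COc2cccc(F)c2F)nc(-c2ccccn2)n1` gives 3.2. The step of a number 0.10 log units lower from compound 1 to compound 2 (within the scatter) comes from the change (4-fluorophenyl in place of 3-fluorophenyl on an oxygen on a saturated carbon), which is how the cores of compound 1 and compound 2 differ. The step of a number 0.10 log units higher from compound 1 to compound 3 (within the scatter) comes from the change (fluoro in place of hydrogen on an aromatic carbon), placed on an aromatic carbon of a six-membered aromatic ring of carbon only, ortho to a fluoro group and ortho to a large group.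

Compound 4 `Cc1cc(COc2ccc(F)cc2F)nc(-c2ccccn2)n1` is not yet measured. It differs from compound 2 by fluoro in place of hydrogen on an aromatic carbon, placed on an aromatic carbon of a six-membered aromatic ring of carbon only, ortho to a large group and meta to a fluoro group. This is the same kind of change as from compound 1 to compound 3, though the surroundings of the place differ as stated. A step of about the same size is expected, a number 0.10 log units higher from compound 2 to compound 4 (within the scatter), resting on the earlier a number 0.10 log units higher from compound 1 to compound 3 (within the scatter). Compound 4 is therefore estimated at 3.1, between 2.8 and 3.4.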

Compound 4, distribution coefficient: 3.1
Beside the measured number, compound 4's estimate shows no gap at the digits printed; the range from low to high includes it.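

In this assay, fluoro in place of hydrogen gives a number 0.10 log units higher from compound 2 to compound 4 (within the scatter) and, on the other core, a number 0.10 log units higher from compound 1 to compound 3 (within the scatter) as the earlier case of the same kind of change. The two steps print at the same size and the surroundings of the place differ, so the change carried from one core to the other without a step beyond the scatter, but each step lies within the scatter, so neither is shown to differ from no step at all, and one pair of cores gives no rule for the series. No measurement at hand accounts for either step.

The compounds shown leave open whether a step beyond the scatter appears in this assay when a group other than fluoro, such as an amine or a carboxylic acid, stands on the same six-membered aromatic ring of carbon only. They also leave open whether such a group would carry from one core to the other as the fluoro group does here.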